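The source may report more compounds than this note shows. Statements on the series, on what has been measured and on what is new or still open speak of the compounds shown alone.

Working notes on the series. Compound 2 `CC1=CC[C@@H]([C@@](C)(O)CCCC(C)(C)NC(=S)N/N=C\c2ccc(Cl)cc2)CC1` is the reference point. Going by the values given here, in a functional assay on HT-29 cells (Homo sapiens) for cytotoxicity, read by sulforhodamine B assay (on this read-out lower numbers stand for stronger inhibition of growth and higher numbers for weaker inhibition of growth), compound 2 gives 22600 nM, the only number in the set. Compound 1 `CC1=CC[C@@H]([C@@](C)(O)CCCC(C)(C)NC(=S)N/N=C\c2ccccc2Cl)CC1` returns only a limit in this assay, at > 100000 nM, which is the upper boundary of the assay (the limit of > 100000 nM in this assay, at which 1 of the 2 values shown sits). The step of an at least 4.4-fold lower number from compound 1 to compound 2 (0.64 log units; beyond the scatter) is therefore bounded on one side only.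

Compound 3 `CC1=CC[C@@H]([C@@](C)(O)CCCC(C)(C)NC(=S)N/N=C(/C)c2ccccc2)CC1` carries the change a group of 9 heavy atoms (8 carbon, 1 nitrogen; one six-membered aromatic ring of carbon only) in place of a group of 9 heavy atoms (7 carbon, 1 nitrogen, 1 chlorine; one six-membered aromatic ring of carbon only), on an amide-type nitrogen: in words, a group of 9 heavy atoms (8 carbon, 1 nitrogen; one six-membered aromatic ring of carbon only) in place of a group of 9 heavy atoms (7 carbon, 1 nitrogen, 1 chlorine; one six-membered aromatic ring of carbon only), on an amide-type nitrogen. The chlorine is lost and a methyl is added on the carbon with a double bond to nitrogen. Among the compounds with values here, no measured step covers this change; the one step in hand moves the chlorine rather than removing it, so it is only a loose guide. A modest weakening is expected, the step from compound 2 to compound 3 being estimated at a 2.0-fold higher number from compound 2 to compound 3 (0.30 log units; within the scatter). Compound 3 is expected at 45000 nM, with a range from 15000 nM to 110000 nM.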

Compound 3, concentration for total growth inhibition: > 100000 nM
Compound 3 gave a limit, no number; the forecaster's own chance of this, stated with the estimate: 35%; middle value at least 2.2-fold (0.34 log units) from the limit.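

In this assay, the exchange on the amide-type nitrogen gives an at least 4.4-fold higher number from compound 2 to compound 3 (0.64 log units; beyond the scatter). Removing the chlorine and adding a methyl on the carbon with a double bond to nitrogen therefore loses the measurable growth inhibition of compound 2, and the printed size is a lower bound only. Among the three compounds, a number appears only with the 4-chlorophenyl group of compound 2, whereas compound 1 and compound 3 both return a limit rather than a number, so the step between these two cannot be read: the limit of > 100000 nM in this assay, at which 2 of the 3 values shown sit.

This change alters two things at once, and the compounds shown do not separate the loss of the chlorine from the gain of the methyl. Also open, going by these compounds, is how the plain phenyl without the methyl, or the 4-chlorophenyl group with the methyl, would read in this assay, and whether a 4-bromophenyl or 4-methoxyphenyl group would hold, improve or lose the value of compound 2.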